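Chloro removal on the shared core: cytotoxicity in lung cells

A few compounds are considered here, and "the series" means these few. Any claim that something is new, unique, unknown or untested is made for them only; others in the source may bear on it.

Compound 1, `COc1cc(/C=C/C(=O)C2=C(/C=C/c3ccc(O)c(OC)c3)NC(=O)NC2c2c(Cl)cccc2Cl)ccc1O`, in a functional assay on QG-56 cells (Homo sapiens) for cytotoxicity, read by MTT assay, with a stated time of 48 h (a lower number here means a stronger inhibitor, a higher number a weaker inhibitor), gives 100000 nM.
Compound 2, `COc1cc(/C=C/C(=O)C2=C(/C=C/c3ccc(O)c(OC)c3)NC(=O)NC2c2ccccc2Cl)ccc1O`, in this assay gives 100000 nM.
Compound 3, `COc1cc(/C=C/C(=O)C2=C(/C=C/c3ccc(O)c(OC)c3)NC(=S)NC2c2c(Cl)cccc2Cl)ccc1O`, in this assay gives 100000 nM.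

All three measured compounds sit at the same reading in this assay. Compound 2 differs from compound 1 by a single change, (hydrogen in place of chloro on an aromatic carbon), and that change gave no change at the digits printed from compound 1 to compound 2 (within the scatter). Compound 3 carries a different core from compound 1; the difference between the two cores is not broken down here, and the two readings are level with each other within the scatter.

Compound 4, `COc1cc(/C=C/C(=O)C2=C(/C=C/c3ccc(O)c(OC)c3)NC(=S)NC2c2ccccc2Cl)ccc1O`, is not yet measured. It stands to compound 3 as compound 2 stands to compound 1: the change is hydrogen in place of chloro on an aromatic carbon, at a place described in the same words as before, so it is the same change made on the other core. For compound 4 the step from its parent is expected to be no change at the digits printed from compound 3 to compound 4 (within the scatter). That expectation rests on compound 1 and compound 2, where the matching change gave no change at the digits printed from compound 1 to compound 2 (within the scatter). Compound 4 is therefore expected at 100000 nM.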

Compound 4, half-maximal inhibitory concentration: 50000 nM
The estimate for compound 4 lay 2.0-fold (0.30 log units) above the measured number; the measured number falls inside the stated range.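

In this assay, cutting 2,6-dichlorophenyl back to 2-chlorophenyl on the second core gave a 2.0-fold lower number from compound 3 to compound 4 (0.30 log units; within the scatter). Set beside the same change on the first core, the two steps cannot be told apart, so in this small set the change carries from one core to the other without a visible difference: the same change on two cores in this assay, no change at the digits printed (within the scatter) from compound 1 to compound 2 and a 2.0-fold lower number (0.30 log units; within the scatter) from compound 3 to compound 4, 2.0-fold (0.30 log units) apart, within the scatter of two such steps This does not show that compound 4 is separated from compound 3 in this assay, and two matched pairs say nothing about how the change would behave on any further core.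

The compounds shown leave open what a plain phenyl ring, with the remaining chloro also gone, would give on either core. They also leave open whether a different group in place of the chloro, such as a methoxy group, a nitrile or an amine, would move the reading in this assay beyond the scatter.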